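Swapping phenethyl for 4-methoxyphenyl in a cell toxicity test

A few compounds are considered here, and "the series" means these few. Any claim that something is new, unique, unknown or untested is made for them only; others in the source may bear on it.

Compound 1 `CCC(C)(C)NC(=O)COC(=O)c1ccc([N+](=O)[O-])o1` gives > 100000 nM (a limit of the assay)
Compound 2 `CC(C)(C)N(CCCc1ccccc1)C(=O)COC(=O)c1ccc([N+](=O)[O-])o1` gives "not active" (no number reported)

Both results come from an ADME assay on HEK-293T cells (Homo sapiens) for cytotoxicity, read by MTT assay, with a stated time of 3 days (on this read-out lower numbers stand for higher toxicity in this test and higher numbers for lower toxicity in this test), and neither is an exact number. Compound 1 sits at a limit of the test with > 100000 nM and no true figure. Compound 2 has no single number and is reported as "not active" (no number reported) in this record.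

The untested compound 3 `COc1ccc(CN(C(=O)COC(=O)c2ccc([N+](=O)[O-])o2)C(C)(C)C)cc1` keeps the shared core. The change 4-methoxyphenyl in place of phenethyl on a saturated chain carbon bound to an amide-type nitrogen puts 4-methoxyphenyl in place of phenethyl on a saturated chain carbon bound to an amide-type nitrogen. Within the data shown here, no measured pair shows what such a swap does. With compound 2 reported as "not active" (no number reported) as the starting point, the expectation in this assay is no step beyond the usual scatter, in either direction. Compound 3 is estimated at 100000 nM (30000 nM to 200000 nM) and may well be reported only as a limit.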

Compound 3, half-maximal cytotoxic concentration: > 100000 nM
Compound 3 was reported as a limit; the forecaster's own chance of this, stated with the estimate: 80%; the middle value sits exactly at the limit.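

In this assay compound 3 gives > 100000 nM, which is a limit of the assay and not a number. Among these compounds, compound 2 is reported as "not active" (no number reported), so no step from compound 2 to compound 3 can be read. The compounds shown leave open what swapping phenethyl for 4-methoxyphenyl does in this assay.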